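A Phenyl Replaces 3-Fluorobenzyl on an Aromatic Nitrogen

A few compounds are considered here, and "the series" means these few. Any claim that something is new, unique, unknown or untested is made for them only; others in the source may bear on it.

Measured compounds and values:
- compound 1, `CCOC(=O)c1ccc(-c2nn(Cc3cccc(F)c3)c3ccccc23)cc1`: > 10000 nM
- compound 2, `COC(=O)c1ccc(-c2nn(Cc3ccccc3)c3ccccc23)cc1`: > 10000 nM
- compound 3, `OCc1ccc(-c2nn(Cc3ccccc3)c3ccccc23)cc1`: > 10000 nM

Compound 1 was tested in a functional assay on cells (Platelet, Homo sapiens) for inhibition; a lower number here means a stronger inhibitor, a higher number a weaker inhibitor. In this assay compound 1 gives > 10000 nM, which is a limit of the assay rather than a number. Compound 2 likewise gives > 10000 nM, also a limit. Compound 3 gives > 10000 nM, again a limit. Within the data shown here, all three measured values sit at the same limit (the limit of > 10000 nM in this assay, at which 3 of the 3 values shown sit), and the single comparable step, a step that the two limits leave unreadable from compound 2 to compound 3, cannot be read from two limits.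

Compound 4 `CCOC(=O)c1ccc(-c2nn(-c3ccccc3)c3ccccc23)cc1` differs from compound 1 in one place: phenyl in place of 3-fluorobenzyl on an aromatic nitrogen. Among the measured compounds shown here, none of the measured compounds differ from one another in the group on the aromatic nitrogen, so no measured step bears on this change. Compound 1 stands at the limit, with no number beneath it to build on. With every measured compound at the limit, compound 4 is expected to remain there too, at an estimated 20000 nM within a range from 5000 nM to 100000 nM. The expected step, a step that the limit leaves unreadable from compound 1 to compound 4, amounts to no change beyond the scatter that these limits allow to be seen.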

Compound 4, half-maximal inhibitory concentration: > 10000 nM
Compound 4: no number, only a limit; the forecaster's own chance of this, stated with the estimate: 85%; the middle value does not contradict the limit.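

The comparison of compound 1 with compound 4 yields no readable step, because each result is a limit of the assay and not a number: the limit of > 10000 nM in this assay, at which 4 of the 4 values shown sit. The compounds shown leave open whether phenyl and 3-fluorobenzyl on the aromatic nitrogen differ in inhibition, and which change to this shared core would give a measurable value.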